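This account rests on a few compounds, and the source may have more. Where it says the series, first, only, none or still open, it means among the compounds named here.

Measured compounds:
- compound 1, `O=C1CSC(c2ccccc2)N1n1c(CSc2nnc(-c3ccncc3)o2)nc2ccccc2c1=O`, 30.1%
- compound 2, `COc1ccc(/C=N/n2c(CSc3nnc(-c4ccncc4)o3)nc3ccccc3c2=O)cc1`, 20%
- compound 3, `O=c1c2cc(Br)ccc2nc(CSc2nnc(-c3ccncc3)o2)n1/N=C/c1ccccc1`, 19.4%

In a functional assay on the whole organism (strain Charles-Foster albino) for inhibition, with Rattus norvegicus as the target, read by paw edema, at a dose of 50 mg/kg by the oral route (on this read-out higher numbers stand for more inhibition at the one dose given (going by the name of the read-out) and lower numbers for less inhibition), compound 3 shows the lowest number of the three, although compound 2 sits within the usual scatter of it, while compound 1 lies higher by more than the scatter. Compound 4, `O=c1c2ccccc2nc(CSc2nnc(-c3ccncc3)o2)n1/N=C/c1ccccc1`, differs from compound 3 in one place: hydrogen in place of bromo on an aromatic carbon. Among the measured compounds shown here, the only step measured so far, a number 10.1 percentage points lower from compound 1 to compound 2 (beyond the scatter), concerns a different part of the shared core and a different kind of exchange, so it does not bear on this change. For the measured compounds named here, no measured pair shows what removing the bromo does. The expectation for compound 4 is therefore a step of about a number 0.6 percentage points higher from compound 3 to compound 4 (within the scatter), nothing beyond the scatter. Compound 4 is estimated at 20%, with a range from 9% to 31%.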

Compound 4, a percentage reported as inhibition, in the whole organism at one dose (the size of the read-out at that dose, not a potency): 16.3%
Compound 4: middle estimate off by 3.7 percentage points, on the high side, and the stated range covers the measured number.
By their numbers in this assay, from the lowest: compounds 4, 3 and 2 (each within the scatter of the next); then compound 1.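

In this assay, hydrogen in place of bromo gives a number 3.1 percentage points lower from compound 3 to compound 4 (within the scatter), so this exchange on the aromatic carbon of the fused system has no effect that can be told from the scatter, and hydrogen in place of methoxy, with a number 3.7 percentage points lower from compound 2 to compound 4 (within the scatter), likewise has none. The larger exchange on the aromatic nitrogen does stand out, with a number 13.8 percentage points lower from compound 1 to compound 4 (beyond the scatter). Nothing available explains these numbers. Still open, from the compounds shown here alone, is whether an amine or a carboxylic acid on that aromatic carbon would move the number beyond the scatter, and whether bromo matters any more on the core of compound 1.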